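Anilino-to-benzylamino switch on the tricyclic quinone core

The source may report more compounds than this note shows. Statements on the series, on what has been measured and on what is new or still open speak of the compounds shown alone.

Measured so far:
- compound 1 `Cc1ccc(NC2=CC(=O)c3c(nc4n3[C@H]3OC[C@@H](O)[C@H]3OC4)C2=O)cc1C`: 4950 nM
- compound 2 `CCc1ccc(NC2=CC(=O)c3nc4n(c3C2=O)[C@H]2OC[C@@H](O)[C@H]2OC4)cc1`: 960 nM
- compound 3 `O=C1C=C(NC2CCCCC2)C(=O)c2c1nc1n2[C@H]2OC[C@@H](O)[C@H]2OC1`: a limit, > 8000 nM

In a functional assay on MCF7 cells (Homo sapiens) for inhibition, read by sulforhodamine B assay (a higher number here means a weaker inhibitor, a lower number a stronger inhibitor), compound 1 gives 4950 nM, the higher of the two numbers shown, with compound 2 giving a lower number in this assay, wait—stated plainly: compound 2 gives 960 nM. Compound 3 gives only a limit in this assay, > 8000 nM.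

Compound 4 `O=C1C(NCc2ccccc2)=CC(=O)c2c1nc1n2[C@H]2OC[C@@H](O)[C@H]2OC1` differs from compound 1 by benzyl in place of 3,4-dimethylphenyl on an amine nitrogen. Going by the values given here, the one measured step that bears on it is an at least 8.3-fold higher number from compound 2 to compound 3 (0.92 log units; beyond the scatter), where the aryl group on the amine nitrogen is exchanged for a saturated ring and the number runs past the limit (the limit of > 8000 nM in this assay, at which 1 of the 3 values shown sits). Benzyl keeps an aromatic ring but moves it one bond from the nitrogen, so a weaker result is expected, a 2.0-fold higher number from compound 1 to compound 4 (0.31 log units; beyond the scatter). Compound 4 is therefore estimated at 10000 nM, within 4000 nM to 30000 nM, with a fair chance that this assay returns only a limit.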

Compound 4, half-maximal inhibitory concentration: > 8000 nM
Compound 4: only a limit was reported (the forecaster's own chance of this, stated with the estimate: 50%); the middle value is on the limit's open side.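

In this assay compound 4 gives only a limit, > 8000 nM. The step reads an at least 1.6-fold higher number from compound 1 to compound 4 (0.20 log units; that floor lies within the scatter), so the size of the change with benzyl in place of 3,4-dimethylphenyl stays unfixed, and its floor alone does not separate the pair. Benzyl keeps an aromatic ring, yet compound 4 sits at the same limit as the cyclohexyl compound 3: the limit of > 8000 nM in this assay, at which 2 of the 4 values shown sit.

How far compound 3 and compound 4 lie past that limit cannot be read, so no order between them can be given. Also open, as far as these compounds go, is what a 2-phenylethyl or 4-methoxyphenyl group on the amine nitrogen would give.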